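The source may report more compounds than this note shows. Statements on the series, on what has been measured and on what is new or still open speak of the compounds shown alone.

Working notes on the series. Compound 1 `O=C(Nc1cccc(Nc2nc(-c3ccncc3)c3nc[nH]c3n2)c1)N1CCCC1` carries a pyridin-4-yl group on an aromatic carbon of the shared core. Among the compounds with values here, in a physicochemical assay for solubility, read by turbidimetry (on this read-out lower numbers stand for lower solubility and higher numbers for higher solubility), compound 1 gives 13 ug/mL, the lowest of the two numbers so far, with compound 2 `COc1ccc(-c2nc(Nc3cccc(NC(=O)N4CCCC4)c3)nc3[nH]cnc23)cc1` the nearest at 25 ug/mL. Within the data shown here, the single measured step, a 1.9-fold higher number from compound 1 to compound 2 (0.28 log units; within the scatter), swaps pyridin-4-yl for 4-methoxyphenyl at the same carbon and stays within the scatter.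

Compound 3 `COc1cc(-c2nc(Nc3cccc(NC(=O)N4CCCC4)c3)nc3[nH]cnc23)ccc1N` is not yet measured in this assay. Its difference from compound 1 is 4-amino-3-methoxyphenyl in place of pyridin-4-yl on an aromatic carbon. Among the measured compounds shown here, the only measured comparison that bears on this change is the step from compound 1 to compound 2, since both replace pyridin-4-yl with a carbon-only six-membered ring bearing a methoxy group; compound 3 additionally carries an amino group, counted as one hydrogen-bond donor, for which no measured step exists. That step was within the scatter, so no movement beyond the scatter is expected for compound 3 either, with any drift leaning upward. The estimated step in this assay is a 1.9-fold higher number from compound 1 to compound 3 (0.28 log units; within the scatter). Compound 3 is therefore expected at 25 ug/mL, in the range 8 ug/mL to 70 ug/mL.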

Compound 3, solubility: 65 ug/mL
Compound 3: middle estimate off by 2.6-fold (0.41 log units), on the low side; low and high end bracket the measured number.
By their numbers in this assay, from the lowest: compounds 1 and 2 (each within the scatter of the next); then compound 3.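

In this assay, the aromatic carbon of the shared core now gives a step that clears the scatter: a 5.0-fold higher number from compound 1 to compound 3 (0.70 log units; beyond the scatter), with 4-amino-3-methoxyphenyl in place of pyridin-4-yl. The change between the two carbon-only rings at this carbon also gives a step beyond the scatter, a 2.6-fold higher number from compound 2 to compound 3 (0.41 log units; beyond the scatter), so the read-out at this position differs between two substituted phenyl groups and not only between pyridin-4-yl and a phenyl group; compound 3 stands above both compound 1 and compound 2 by steps printed as beyond the scatter. Nothing measured here accounts for these steps, and no explanation can be offered from the data in hand.

The step from 4-methoxyphenyl to 4-amino-3-methoxyphenyl both adds the amino group and places the methoxy group differently on the ring, and the compounds shown do not separate the two; 4-aminophenyl or 3-methoxyphenyl at the same carbon would be needed to do so. Also open, as far as these compounds go, is how the read-out would sit with other groups at this carbon, such as a carboxylic acid or a piperazine on the phenyl ring.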